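The source may report more compounds than this note shows. Statements on the series, on what has been measured and on what is new or still open speak of the compounds shown alone.

Compound 1, `N#CC1=C(N)N(c2ccc(S(N)(=O)=O)cc2)C2=C(C(=O)CCC2)C1c1ccc(Cl)cc1Cl`: in a functional assay on Ehrlich cells (Mus musculus) for cytotoxicity, read by trypan blue exclusion, with a stated time of 2 h (a lower number here means a stronger inhibitor, a higher number a weaker inhibitor), compound 1 gives 25 ug/mL.
Compound 2, `CC(Cl)CC(=O)NC1=C(C#N)C(c2ccc(Cl)cc2Cl)C2=C(CCCC2=O)N1c1ccc(S(N)(=O)=O)cc1`: in this assay compound 2 gives 25 ug/mL.
Compound 3, `Cc1ccc(C(=O)NC2=C(C#N)C(c3ccc(Cl)cc3Cl)C3=C(CCCC3=O)N2c2ccc(S(N)(=O)=O)cc2)cc1`: in this assay compound 3 gives > 100 ug/mL, which is a limit of the assay and not a number.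

Compound 3 therefore stands at the limit of > 100 ug/mL in this assay, at which 1 of the 3 values shown sits, and its true value is known only as lying past that point. Both measured steps that lead to it point the same way: an at least 4.0-fold higher number from compound 1 to compound 3 (0.60 log units; beyond the scatter) and an at least 4.0-fold higher number from compound 2 to compound 3 (0.60 log units; beyond the scatter), each at least modest and beyond the scatter.

Compound 4, `N#CC1=C(NC(=O)c2ccc([N+](=O)[O-])cc2)N(c2ccc(S(N)(=O)=O)cc2)C2=C(C(=O)CCC2)C1c1ccc(Cl)cc1Cl`, differs from compound 3 by nitro in place of methyl on an aromatic carbon. Within the data shown here, no measured step changes a group on that ring, so none of the three steps bears directly on this exchange; the two steps that reach compound 3 only show that the (4-methylphenyl)carbonyl analogue sits at the limit. The expected step of a number no higher from compound 3 to compound 4 (the limit leaves the size open) is accordingly no change beyond the scatter. For compound 4 the estimate in this assay is 100 ug/mL, with a range from 40 ug/mL to 300 ug/mL.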

Compound 4, half-maximal inhibitory concentration: 50 ug/mL
The estimate for compound 4 lay 2.0-fold (0.30 log units) above the measured number; the range from low to high includes it.
By their numbers in this assay, from the lowest: compounds 1, 2 and 4 (each within the scatter of the next). At a limit, above all of these: compound 3.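

The exchange of nitro in place of methyl is the only change shown on this aromatic ring, and in this assay it gives an at least 2.0-fold lower number from compound 3 to compound 4 (0.30 log units; that floor lies within the scatter). (4-Nitrophenyl)carbonyl in place of hydrogen on the amine nitrogen gives a 2.0-fold higher number from compound 1 to compound 4 (0.30 log units; within the scatter), and 4-nitrophenyl in place of 2-chloropropyl gives a 2.0-fold higher number from compound 2 to compound 4 (0.30 log units; within the scatter), so a phenylcarbonyl group on that nitrogen does not by itself go with a number past the limit. The full size of the exchange stays open because compound 3 is held at a limit of the assay and not a number: the limit of > 100 ug/mL in this assay, at which 1 of the 4 values shown sits.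

On these data alone, whether an amine, a methoxy group or a chlorine at this place would read with compound 4 or with compound 3 remains open. Also open, as far as these compounds go, is how a longer chain on the carbonyl carbon would read in this assay.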